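This account rests on a few compounds, and the source may have more. Where it says the series, first, only, none or still open, it means among the compounds named here.

Compound 1, `NC(=O)c1cnc(N2CCC(Oc3ccccc3C(F)(F)F)CC2)s1`: 3 nM
Compound 2, `NC(=O)c1csc(N2CCC(Oc3ccccc3C(F)(F)F)CC2)n1`: 676 nM

In an assay on microsomes from liver (strain Wistar) for inhibition of acyl-CoA desaturase 1 (Rattus norvegicus), read by HPLC, with stated times of 1 h and 60 min (on this read-out lower numbers stand for stronger inhibition and higher numbers for weaker inhibition), compound 1 gives 3 nM and compound 2 gives 676 nM. Going by the values given here, compound 2 stands highest of the two numbers measured, so it is the weaker inhibitor of the pair; the only measured step, a 230-fold higher number from compound 1 to compound 2 (2.35 log units; beyond the scatter), comes from a 4-carbamoyl-1,3-thiazol-2-yl taking the place of a 5-carbamoyl-1,3-thiazol-2-yl on an amine nitrogen in a ring. Compound 3, `NC(=O)c1nnc(N2CCC(Oc3ccccc3C(F)(F)F)CC2)s1`, has not been measured. It differs from compound 2 in one place: 5-carbamoyl-1,3,4-thiadiazol-2-yl in place of 4-carbamoyl-1,3-thiazol-2-yl on an amine nitrogen in a ring. The group that enters again carries a 5-carbamoyl, as the 5-carbamoyl-1,3-thiazol-2-yl of compound 1 does, while the ring itself changes. Among the compounds with values here, the single step of a 230-fold higher number from compound 1 to compound 2 (2.35 log units; beyond the scatter) is the only guide, and it was large; returning to a 5-carbamoyl arrangement is therefore expected to give a large drop in this assay, roughly undoing that step, though the ring change has no measured counterpart and adds uncertainty. Compound 3 is expected to reach 10 nM, within 2 nM to 60 nM, which means an expected step of a 68-fold lower number from compound 2 to compound 3 (1.83 log units; beyond the scatter).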

Compound 3, half-maximal inhibitory concentration: 3 nM
Estimate against measurement, compound 3: 3.3-fold (0.52 log units) above; the range from low to high includes it.
By their numbers in this assay, from the lowest: compounds 1 and 3 (each within the scatter of the next); then compound 2.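

In this assay, the change to the 5-carbamoyl-1,3,4-thiadiazol-2-yl group gives a 230-fold lower number from compound 2 to compound 3 (2.35 log units; beyond the scatter), a large step that alters both where the carbamoyl sits and the make-up of the ring. The other step separates these two changes: going from a five-membered aromatic ring with 2 hetero atoms to one with 3, with the carbamoyl kept in the 5 position, gives no change at the digits printed from compound 1 to compound 3 (within the scatter), so among these three compounds the carbamoyl position tracks the large difference and the ring change does not. Nothing measured here explains why these two groups match while the 4-carbamoyl-1,3-thiazol-2-yl group of compound 2 falls so far behind.

All three compounds carry a carbamoyl group, so the compounds shown leave open whether it is needed at all, and what a carboxylic acid or a nitrile in its place would do. Going by these compounds, they also share the rest of the core, so it remains open whether the match between the two ring types would hold with a different group on the six-membered non-aromatic ring.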